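The source may hold more compounds than are shown below. What is called first, only, known or untested is meant among the compounds shown, and "the series" means these compounds.

Of the compounds shown here, three from this series have been tested in a functional assay on HepG2 cells (Homo sapiens) for inhibition, read by MTT assay, with a stated time of 72 h, tested at 30 uM; on this read-out higher numbers stand for more inhibition of growth at the one concentration tested and lower numbers for less inhibition of growth. Compound 1 `C=CCc1ccc(OCc2cn(-c3ccccc3Cl)nn2)c(O)c1` gives 2.5%, compound 2 `C=CCc1ccc(OCc2cn(-c3cccc(C#N)c3)nn2)c(O)c1` gives 2.3%, and compound 3 `C=CCc1ccc(OCc2cn(-c3ccc(Br)cc3)nn2)c(O)c1` gives 8.9%. Compound 2 sits within the scatter of both of its neighbours: the step of a number 0.2 percentage points lower from compound 1 to compound 2 (within the scatter) and the step of a number 6.6 percentage points higher from compound 2 to compound 3 (within the scatter) are each within the usual spread of repeated measurements, as is the step of a number 6.4 percentage points higher from compound 1 to compound 3 (within the scatter). All three numbers therefore describe essentially the same weak effect.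

Compound 4 `C=CCc1ccc(OCc2cn(-c3cccc([N+](=O)[O-])c3)nn2)c(O)c1` is not yet measured. It differs from compound 2 in one place, (nitro in place of cyano on an aromatic carbon), the position being on an aromatic carbon of a six-membered aromatic ring of carbon only, meta to a large group.

The three measured steps all change the group on the aromatic nitrogen and bear on this change, and none of them moved the number beyond the scatter. On that basis no step beyond the scatter is expected in this assay for compound 4, in either direction. Compound 4 is estimated to give 4%, within a range from -6% to 14%, which is expected to mean a step of a number 1.7 percentage points higher from compound 2 to compound 4 (within the scatter).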

Compound 4, percent growth inhibition at one concentration: 15.2%
Beside the measured number, compound 4's estimate is 11.2 percentage points below it; measured number outside the range, above it.
By their numbers in this assay, from the lowest: compounds 2, 1, 3 and 4 (each within the scatter of the next, the first and the last beyond it).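

In this assay, the change of cyano to nitro gives a number 12.9 percentage points higher from compound 2 to compound 4 (beyond the scatter), while the three earlier steps, which all exchanged the group on the aromatic nitrogen, stayed within the scatter. The read-out therefore responds to a change at this position, on an aromatic carbon of a six-membered aromatic ring of carbon only and meta to a large group, even though the swap is small: one more heavy atom and one more hydrogen-bond acceptor by the computed counts, with oxygen entering where the cyano carbon leaves. Nothing given here measures what lies behind this modest step, so the counted differences cannot be tied to it.

Going by these compounds, it remains open whether the step belongs to nitro specifically or would also appear with an amine, a carboxylic acid or a methoxy group at the same position, which would show whether the number follows the group that enters or simply the loss of cyano. On these data alone, it is also open whether compound 4 would keep its place across a range of concentrations, as all the numbers here come from a single concentration.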